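The source may report more compounds than this note shows. Statements on the series, on what has been measured and on what is new or still open speak of the compounds shown alone.

Measured compounds in a functional assay on CHO cells for antagonist activity at gastric inhibitory polypeptide receptor (Homo sapiens), read by scintillation counting and cAMP accumulation, with a stated time of 30 min; on this read-out higher numbers stand for weaker inhibition and lower numbers for stronger inhibition:
compound 1 `CCCOc1ccc(-c2cc(-c3cc(Cl)cc(Cl)c3)nn2Cc2ccc(C(=O)NCCC(=O)O)cc2)cc1Cl`, 3370 nM
compound 2 `COc1cc(Cl)cc(-c2cc(-c3ccc4cc(OC)ccc4c3)n([C@@H](C)c3ccc(C(=O)NCCC(=O)O)cc3)n2)c1`, 5000 nM
compound 3 `CC(C)c1ccc2cc(-c3cc(-c4cc(Cl)cc(Cl)c4)nn3[C@@H](C)c3ccc(C(=O)NCCC(=O)O)cc3)ccc2c1`, 431 nM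

Compound 3 gives the lowest number of the three; compound 1 and compound 2 both lie beyond the scatter above it. Within the data shown here, no pair of these measured compounds differs in only one place, so no single step is isolated. Compound 4 `CCOc1ccc2cc(-c3cc(-c4cc(Cl)cc(Cl)c4)nn3[C@@H](C)c3ccc(C(=O)NCCC(=O)O)cc3)ccc2c1` differs from compound 3 by ethoxy in place of isopropyl on an aromatic carbon. Compound 2 resembles compound 4 in part, yet it differs from compound 3 in more than one place, so its value does not isolate this change. For the step from compound 3 to compound 4 a modest weakening is expected, close to the scatter, a 1.7-fold higher number from compound 3 to compound 4 (0.24 log units; within the scatter). Compound 4 is therefore estimated at 750 nM in this assay, within 250 nM to 2200 nM.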

Compound 4, half-maximal inhibitory concentration: 885 nM
Beside the measured number, compound 4's estimate is 1.2-fold (0.07 log units) below it; low and high end bracket the measured number.
By their numbers in this assay, from the lowest: compound 3; then compound 4; then compounds 1 and 2 (each within the scatter of the next).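

In this assay the series now has its first single-place comparison: ethoxy in place of isopropyl on this aromatic carbon gives a 2.1-fold higher number from compound 3 to compound 4 (0.31 log units; beyond the scatter) and is a modest step. The position therefore responds to this exchange, in which one carbon gives way to an oxygen and one hydrogen-bond acceptor enters. Nothing available accounts for the step.

Going by these compounds, whether the oxygen or the shape of the group matters remains open. A butoxy chain or a dimethylamino group on this carbon would bear on that question.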